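Chain lengthening from compound 3 to compound 4

The compounds below may be only part of what the source reports. "The series", "measured", "known", "first", "only" and "open" are said of these compounds alone.

- Compound 1 `CCCCCCCCOc1cc(OC)ccc1C(C)=O`: 69400000 nM
- Compound 2 `CCCCCCCCCCCCOc1cc(OC)ccc1C(C)=O`: 65600000 nM
- Compound 3 `CCCCCCCCCCCCCCOc1cc(OC)ccc1C(C)=O`: 57000000 nM

All three values come from a functional assay, with a stated time of 10 min; on this read-out lower numbers stand for stronger inhibition and higher numbers for weaker inhibition. Compound 3 stands within the scatter of both other compounds, so the numbers do not separate it from them. Compound 4 `CCCCCCCCCCCCCCCCOc1cc(OC)ccc1C(C)=O` differs from compound 3 as follows: ethyl in place of hydrogen on a saturated chain carbon, ten or more bonds along the chain from an oxygen on an aromatic ring. The same ethyl change gave a 1.2-fold lower number from compound 2 to compound 3 (0.06 log units; within the scatter). Larger chain additions gave a 1.1-fold lower number from compound 1 to compound 2 (0.02 log units; within the scatter) and a 1.2-fold lower number from compound 1 to compound 3 (0.09 log units; within the scatter). With all three steps inside the scatter, no step beyond the scatter is expected in this assay. The expected step is a 1.1-fold lower number from compound 3 to compound 4 (0.02 log units; within the scatter). The estimate for compound 4 is 54000000 nM, with an expected range of 33000000 nM to 85000000 nM.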

Compound 4, half-maximal inhibitory concentration: 61500000 nM
Compound 4: the middle estimate sits 1.1-fold (0.06 log units) below what was measured, within the range that was stated.
By their numbers in this assay, from the lowest: compounds 3, 4, 2 and 1 (each within the scatter of the next).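

In this assay, adding ethyl at this saturated chain carbon gives a 1.1-fold higher number from compound 3 to compound 4 (0.03 log units; within the scatter), while the larger additions give a 1.1-fold lower number from compound 2 to compound 4 (0.03 log units; within the scatter) and a 1.1-fold lower number from compound 1 to compound 4 (0.05 log units; within the scatter). The series now reaches octyl added at this place without any step leaving the scatter, so compounds 1 to 4 are not separated by chain length. Nothing measured here offers an explanation for this result. Still open, from the compounds shown here alone, is whether a longer chain than that of compound 4 would separate from the series, and whether an amine or a carboxylic acid carried on the chain would give a step beyond the scatter.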